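Changing the benzyl group on the sulfur of compound 2

The source may hold more compounds than are shown below. What is called first, only, known or untested is meant among the compounds shown, and "the series" means these compounds.

Measured compounds:
compound 1 `CC1=C(C(=O)Nc2ccc([N+](=O)[O-])cc2)C(c2ccc(Br)cc2)N=C(SCc2ccc(F)cc2)N1` — 27.3%
compound 2 `CC1=C(C(=O)Nc2ccc([N+](=O)[O-])cc2)C(c2cccc([N+](=O)[O-])c2)N=C(SCc2cccc(Cl)c2)N1` — 12.9%

In a functional assay on the whole organism (artery, strain albino) with Rattus norvegicus as the target, with a stated time of 720 min, at a dose of 10 mg/kg by the oral route (on this read-out higher numbers stand for more inhibition at the one dose given (going by the name of the read-out) and lower numbers for less inhibition), compound 2 gives 12.9% and stands lowest of the two, with compound 1 above it by a gap beyond the usual scatter. Compound 3 `CC1=C(C(=O)Nc2ccc([N+](=O)[O-])cc2)C(c2cccc([N+](=O)[O-])c2)N=C(SCc2ccc(F)cc2)N1` has not yet been measured. It differs from compound 2 in one place: 4-fluorophenyl in place of 3-chlorophenyl on a saturated chain carbon bound to a sulfur. Among the measured compounds shown here, no measured pair differs in this place alone, so the size of the step is not known. The step from compound 2 to compound 3 is expected to be small, a number 5.1 percentage points higher from compound 2 to compound 3 (within the scatter), upward but within the scatter. Compound 3 is therefore estimated at 18%, between 5% and 35%.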

Compound 3, a percentage reported as inhibition, in the whole organism at one dose (the size of the read-out at that dose, not a potency): 20.1%
Compound 3: the middle estimate sits 2.1 percentage points below what was measured; the range from low to high includes it.
By their numbers in this assay, from the lowest: compounds 2, 3 and 1 (each within the scatter of the next, the first and the last beyond it).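

In this assay, 4-fluorophenyl in place of 3-chlorophenyl on a saturated chain carbon bound to a sulfur gives a number 7.2 percentage points higher from compound 2 to compound 3 (within the scatter), so this exchange moves the read-out by no more than the scatter. Compound 3 also opens a second single change, 3-nitrophenyl in place of 4-bromophenyl on a saturated ring carbon, which gives a number 7.2 percentage points lower from compound 1 to compound 3 (within the scatter). Nothing at hand explains either step. On these data alone, what an amine or a carboxylic acid in place of the 4-fluorophenyl would give in this assay remains open.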